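The source may hold more compounds than are shown below. What is called first, only, known or untested is meant among the compounds shown, and "the series" means these compounds.

Three amides on the shared core have been measured in a functional assay on the whole organism for inhibition, with Rattus norvegicus as the target, read by paw edema, at a dose of 100 mg/kg by the oral route; on this read-out higher numbers stand for more inhibition at the one dose given (going by the name of the read-out) and lower numbers for less inhibition: compound 1 `O=C(Nc1ccccn1)c1c(O)c2cccnc2n(-c2ccccc2)c1=O` gives -13.5%, compound 2 `O=C(Nc1cccc([N+](=O)[O-])c1)c1c(O)c2cccnc2n(-c2ccccc2)c1=O` gives 5.7%, and compound 3 `Cc1ccccc1NC(=O)c1c(O)c2cccnc2n(-c2ccccc2)c1=O` gives 11.7%. Going by the values given here, compound 3 holds the highest of the three numbers, yet its gap to compound 2 lies within the scatter; only the step of a number 25.2 percentage points higher from compound 1 to compound 3 (beyond the scatter) stands beyond it. Compound 4 `O=C(Nc1ccncc1)c1c(O)c2cccnc2n(-c2ccccc2)c1=O` differs from compound 3 by pyridin-4-yl in place of 2-methylphenyl on an amide-type nitrogen. This places a pyridin-4-yl where compound 1 carried pyridin-2-yl, so the step of a number 25.2 percentage points higher from compound 1 to compound 3 (beyond the scatter), read backwards, bears on it, though the two pyridinyl groups are not identical. A drop beyond the scatter is therefore expected, a number 13.7 percentage points lower from compound 3 to compound 4 (beyond the scatter). Compound 4 is estimated at -2%, with a range from -20% to 14%.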

Compound 4, a percentage reported as inhibition, in the whole organism at one dose (the size of the read-out at that dose, not a potency): 34.9%
Beside the measured number, compound 4's estimate is 36.9 percentage points below it, outside the stated range (above it).
By their numbers in this assay, from the lowest: compound 1; then compounds 2 and 3 (each within the scatter of the next); then compound 4.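

On the amide-type nitrogen, pyridin-4-yl separates clearly from both aryl groups in this assay, with a number 23.2 percentage points higher from compound 3 to compound 4 (beyond the scatter) and a number 29.2 percentage points higher from compound 2 to compound 4 (beyond the scatter), so compound 4 now stands above every other compound in the series. Going by these compounds alone, the two pyridinyl groups cannot be treated as interchangeable here: pyridin-4-yl in place of pyridin-2-yl gives a number 48.4 percentage points higher from compound 1 to compound 4 (beyond the scatter), the largest step so far. No measurement at hand accounts for this difference.

Open, on these data alone, is whether pyridin-3-yl follows pyridin-4-yl or pyridin-2-yl, and how a carboxylic acid or a longer alkyl chain on the same nitrogen would read. With a single dose, these numbers give no potency.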